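Trifluoromethyl in place of bromo: one change, one estimate

The compounds below may be only part of what the source reports. "The series", "measured", "known", "first", "only" and "open" are said of these compounds alone.

Measured so far:
- compound 1, `O=C(Nc1cccc2[nH]ncc12)NC1CCc2cc(Br)ccc21`: 9 nM
- compound 2, `O=C(Nc1cccc2[nH]ncc12)NC1CCc2cccnc21`: 1350 nM
- compound 3, `Cc1cccc2c1CCC2NC(=O)Nc1cccc2[nH]ncc12`: 46 nM

All three were tested in an assay on isolated protein for inhibition of transient receptor potential cation channel subfamily V member 1 (Homo sapiens), read by calcium flux; a lower number here means a stronger inhibitor, a higher number a weaker inhibitor. Compound 1 has the lowest number of the three. Its nearest neighbour is compound 3, whose number is higher by a margin beyond the scatter; compound 2 sits furthest away, with a much higher number. No pair among these three differs in a single place, so no single step can be isolated from them.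

Compound 4, `O=C(Nc1cccc2[nH]ncc12)NC1CCc2cc(C(F)(F)F)ccc21`, differs from compound 1 in one place: trifluoromethyl in place of bromo on an aromatic carbon. The change keeps the shared core of compound 1 and the position of the substituent unchanged. Among the measured compounds shown here, with no measured pair to lean on, the expectation rests on compound 1 alone, whose 9 nM serves as the anchor. The step from compound 1 to compound 4 in this assay is expected to be small, either direction, and most likely within the scatter. Compound 4 is therefore estimated at 15 nM (range 5 nM to 50 nM), a step of a 1.7-fold higher number from compound 1 to compound 4 (0.22 log units; within the scatter).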

Compound 4, half-maximal inhibitory concentration: 3 nM
Compound 4: the middle estimate sits 5.0-fold (0.70 log units) above what was measured, outside the stated range (below it).
By their numbers in this assay, from the lowest: compound 4; then compound 1; then compound 3; then compound 2.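

This is the only step among the compounds shown that isolates one place, and it shows that the aromatic carbon bearing bromo in compound 1 can take a different group with a gain rather than a loss. Trifluoromethyl in place of bromo brings a 3.0-fold lower number from compound 1 to compound 4 (0.48 log units; beyond the scatter) in this assay and this modest step lies beyond the scatter, even though the entering group has 4 heavy atoms where the leaving one has 1. Nothing measured here accounts for the direction of the step.

As far as these compounds go, whether this gain extends beyond trifluoromethyl remains open, since a chloro group, a nitrile or a methoxy group at the same carbon would test how far the trend from bromo runs. The compounds shown also leave open how much of the gap separating compound 2 and compound 3 from compound 1 traces to this carbon, as neither differs from compound 1 in one place.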